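Working notes: nitrogen-chain variants and macrophage cytotoxicity

The compounds below may be only part of what the source reports. "The series", "measured", "known", "first", "only" and "open" are said of these compounds alone.

Going by the values given here, compound 2 `COC(=O)C1C(=O)C(C(=O)OC)[C@H](c2ccccn2)N(Cc2ccccc2)[C@@H]1c1ccccn1` holds the lowest of the two numbers measured so far in an ADME assay on J774.1 cells (Mus musculus) for cytotoxicity, with a stated time of 48 h (a lower number here means that less compound is needed, a higher number that more compound is needed for the effect), where compound 2 gives 34 uM. Among the compounds with values here, the only neighbour is compound 1 `COC(=O)C1C(=O)C(C(=O)OC)[C@H](c2ccccn2)N(CCCC(=O)O)[C@@H]1c1ccccn1`, and in this assay compound 1 gives 46 uM; the single measured step reads a 1.4-fold lower number from compound 1 to compound 2 (0.13 log units; within the scatter), so the two values sit within the scatter of one another. Compound 3 `COC(=O)C1C(=O)C(C(=O)OC)[C@H](c2ccccn2)N(CCCO)[C@@H]1c1ccccn1` is the next variant and differs from compound 2 by 2-hydroxyethyl in place of phenyl on a saturated chain carbon bound to an amine nitrogen in a ring. Within the data shown here, the one step that bears on this change is a 1.4-fold lower number from compound 1 to compound 2 (0.13 log units; within the scatter), in which swapping 2-carboxyethyl for phenyl at the same place left the number within the scatter. A return to a short chain is therefore expected to change little, and the step from compound 2 to compound 3 is estimated as a 1.3-fold higher number from compound 2 to compound 3 (0.12 log units; within the scatter), leaning if anything toward the number of compound 1. Compound 3 is expected to give about 45 uM in this assay, with a range from 22 uM to 90 uM.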

Compound 3, concentration for half-maximal effect: 32 uM
Beside the measured number, compound 3's estimate is 1.4-fold (0.15 log units) above it, within the range that was stated.
By their numbers in this assay, from the lowest: compounds 3, 2 and 1 (each within the scatter of the next).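

In this assay, putting 2-hydroxyethyl in place of phenyl on the saturated chain carbon bound to the amine nitrogen in a ring (a 1.1-fold lower number from compound 2 to compound 3 (0.03 log units; within the scatter)) swaps an aromatic ring for an open chain with a hydrogen-bond donor and acceptor, yet the two numbers lie within the scatter. Hydroxy in place of carboxy at the chain end (a 1.4-fold lower number from compound 1 to compound 3 (0.16 log units; within the scatter)) also stays within the scatter, so benzyl, 3-hydroxypropyl and the carboxy-ended chain of compound 1 cannot be told apart at this place. No supporting measurement bears on these numbers.

On these data alone, whether an amine, an amide or a longer chain at this place would give a step beyond the scatter remains open. Also open, as far as these compounds go, is whether this reading carries over to a different core.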